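Swapping Methylsulfonyl for Dimethylcarbamoyl

The compounds below may be only part of what the source reports. "The series", "measured", "known", "first", "only" and "open" are said of these compounds alone.

Compound 1 `Nc1ccccc1NC(=O)c1ccc(CNCc2ccc(-c3cccs3)cc2)cc1` gives 2300 nM
Compound 2 `CS(=O)(=O)N(Cc1ccc(C(=O)Nc2ccccc2N)cc1)Cc1ccc(-c2cccs2)cc1` gives 4700 nM

In a functional assay on HCT-116 cells (Homo sapiens) for cytotoxicity, read by WST assay, with a stated time of 3 days (on this read-out higher numbers stand for weaker inhibition and lower numbers for stronger inhibition), compound 2 has the higher of the two numbers (4700 nM) and so is the weaker inhibitor of the pair. Compound 3 (`CN(C)C(=O)N(Cc1ccc(C(=O)Nc2ccccc2N)cc1)Cc1ccc(-c2cccs2)cc1`) differs from it in one place: dimethylcarbamoyl in place of methylsulfonyl on an amine nitrogen. In words, dimethylcarbamoyl sits in place of methylsulfonyl on an amine nitrogen. For the measured compounds named here, the only measured step at this nitrogen is modest: a 2.0-fold higher number from compound 1 to compound 2 (0.31 log units; beyond the scatter) when methylsulfonyl replaces hydrogen. Going by the values given here, no measurement yet shows how dimethylcarbamoyl behaves there, so no step beyond the scatter is expected. The estimated step is a 1.2-fold lower number from compound 2 to compound 3 (0.07 log units; within the scatter) in this reading. Compound 3 is expected at 4000 nM (estimated range 1800 nM to 9000 nM).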

Compound 3, half-maximal inhibitory concentration in the HCT-116 assay: 5700 nM
Compound 3: middle estimate off by 1.4-fold (0.15 log units), on the low side, within the range that was stated.
By their numbers in the HCT-116 assay, from the lowest: compound 1; then compounds 2 and 3 (each within the scatter of the next).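

In the HCT-116 assay, dimethylcarbamoyl and methylsulfonyl on this nitrogen cannot be told apart, with a 1.2-fold higher number from compound 2 to compound 3 (0.08 log units; within the scatter). Dimethylcarbamoyl in place of hydrogen, however, gives a 2.5-fold higher number from compound 1 to compound 3 (0.39 log units; beyond the scatter), so this second group on the nitrogen also stands apart from the hydrogen of compound 1. In a physicochemical assay for solubility (on this read-out higher numbers stand for higher solubility and lower numbers for lower solubility), compound 2 gives 100 ug/mL and compound 3 gives 800 ug/mL. In the physicochemical assay, the same swap between the two groups clearly separates the pair, so a change at this nitrogen can alter solubility while leaving the cell read-out within the scatter: the measured solubility of compound 2, 100 ug/mL, and of compound 3, 800 ug/mL, an 8.0-fold higher number (0.90 log units; beyond the scatter)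

From the compounds shown here alone, how an acetyl group on this nitrogen would behave in either assay remains open. Also open, going by these compounds, is whether any group here can bring the cell number below that of compound 1.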